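From methoxy to 4-chlorobutoxy on compound 2

This account rests on a few compounds, and the source may have more. Where it says the series, first, only, none or still open, it means among the compounds named here.

Measured so far in a functional assay on MCF7 cells (Homo sapiens) for inhibition; on this read-out lower numbers stand for stronger inhibition and higher numbers for weaker inhibition
compound 1 `CCCCCCCC[C@@]1(C)SC(O)=CC1=O` with 12.6 ug/mL
compound 2 `CCCCCC[C@@]1(C)SC(=O)C=C1OC` with 14 ug/mL
compound 3 `CCCCCCCC[C@@]1(C)SC(=O)C=C1OC` with > 50 ug/mL (a limit, not a number)

Within the data shown here, compound 2 at 14 ug/mL and compound 1 at 12.6 ug/mL lie within the scatter of each other, and these are the only two true numbers. Compound 3 stands at > 50 ug/mL as a limit of the assay, not a number.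

Compound 4 `CCCCCC[C@@]1(C)SC(=O)C=C1OCCCCCl` comes from compound 2 by one change, 3-chloropropyl in place of hydrogen on a saturated chain carbon bound to an oxygen on an unsaturated carbon in the form of 3-chloropropyl in place of hydrogen on a saturated chain carbon bound to an oxygen on an unsaturated carbon, which reads as methoxy to 4-chlorobutoxy.

Among the measured compounds shown here, one measured step bears on this, and only indirectly. The step of an at least 3.5-fold higher number from compound 2 to compound 3 (0.55 log units; beyond the scatter) lies beyond the scatter, but it adds ethyl at a different place, on a saturated chain carbon. No change at the methoxy group itself has been measured, so this single precedent transfers with real uncertainty. A move toward weaker inhibition in this assay is expected, of similar size, and a report of only a limit remains possible. The expected step is a 2.3-fold higher number from compound 2 to compound 4 (0.36 log units; beyond the scatter) by this estimate. For compound 4 the estimated value is 32 ug/mL with an expected range from 12 ug/mL to 85 ug/mL as the working figure.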

Compound 4, half-maximal inhibitory concentration: 8.6 ug/mL
Beside the measured number, compound 4's estimate is 3.7-fold (0.57 log units) above it; the measured number lies below the stated range.
By their numbers in this assay, from the lowest: compounds 4, 1 and 2 (each within the scatter of the next). At a limit, above all of these: compound 3.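

In this assay, methoxy to 4-chlorobutoxy is the only change shown at this place, and it gives a 1.6-fold lower number from compound 2 to compound 4 (0.21 log units; within the scatter), so 3-chloropropyl in place of hydrogen on a saturated chain carbon bound to an oxygen on an unsaturated carbon is tolerated on this read-out. The step of an at least 3.5-fold higher number from compound 2 to compound 3 (0.55 log units; beyond the scatter) rests on a limit and lies at another place, on a saturated chain carbon, so it does not carry over to this position. Nothing shown gives a cause for this tolerance.

On these data alone, it remains open whether the chlorine or the chain alone matters here; a plain butoxy, or an amine or a carboxylic acid in place of the chlorine, would separate the two. Also open, as far as these compounds go, is whether the same change is tolerated on the longer chain of compound 3, whose > 50 ug/mL is a limit and not a number.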